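Aryl change at the shared core: notes toward compound 3

The source may report more compounds than this note shows. Statements on the series, on what has been measured and on what is new or still open speak of the compounds shown alone.

Measured so far in a functional assay for inhibition, tested at 80 ug/mL; a higher number here means a stronger effect of the compound at the concentration tested, a lower number a weaker effect:
- compound 1, `Cc1cc(O)c(C(C)C)cc1-c1cc(-c2ccccc2)c(C#N)c(=O)[nH]1`: 58%
- compound 2, `Cc1cc(O)c(C(C)C)cc1-c1cc(-c2cccs2)c(C#N)c(=O)[nH]1`: 63%

Among the measured compounds shown here, compound 1 and compound 2 stand together on these numbers; the only measured step, a number 5 percentage points higher from compound 1 to compound 2 (within the scatter), sits within the scatter, so the two read-outs cannot be told apart. Compound 3, `COc1cc(-c2cc(-c3cc(C(C)C)c(O)cc3C)[nH]c(=O)c2C#N)ccc1O`, remains to be measured in this assay. It differs from compound 1 in one place: 4-hydroxy-3-methoxyphenyl in place of phenyl on an aromatic carbon. For the measured compounds named here, the single step that bears on it is the aryl exchange from compound 1 to compound 2, which changed the read-out by a number 5 percentage points higher from compound 1 to compound 2 (within the scatter) and thus gave no movement beyond the scatter. Going by the values given here, no measured step covers a hydroxy or methoxy bearing aryl at this place. With one aryl exchange at this position showing no effect, the expectation for compound 3 is a step of about a number 2 percentage points higher from compound 1 to compound 3 (within the scatter), that is, none beyond the scatter. Compound 3 is accordingly estimated at 60% in this assay, with a range from 44% to 76%.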

Compound 3, a percentage reported as inhibition, at one concentration (the size of the read-out at that concentration, not a potency): 42%
The estimate for compound 3 lay 18 percentage points above the measured number; the whole stated range lies above it.
By their numbers in this assay, from the lowest: compound 3; then compounds 1 and 2 (each within the scatter of the next).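

This position on the shared core is not indifferent: 4-hydroxy-3-methoxyphenyl on this aromatic carbon gives a number 16 percentage points lower from compound 1 to compound 3 (beyond the scatter) and a number 21 percentage points lower from compound 2 to compound 3 (beyond the scatter) in this assay at the tested concentration. The exchange between phenyl and thiophen-2-yl gave no movement beyond the scatter, so the aryl group here can change the read-out, and the one change beyond the scatter among these compounds is a loss. Nothing measured bears on the origin of this loss.

On these data alone, the hydroxy and methoxy groups enter together in compound 3, so their separate contributions remain open, and 4-hydroxyphenyl or 3-methoxyphenyl at this place would divide them. Also open, as far as these compounds go, is how an aryl group carrying an amine or a carboxylic acid would read out here.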